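Replacing a Branched Chain with a Straight One

This account rests on a few compounds, and the source may have more. Where it says the series, first, only, none or still open, it means among the compounds named here.

Compound 1, with structure `CC(C)(C)c1ccc(CN(Cc2cccc(CCC(=O)O)c2)S(=O)(=O)c2ccccc2)cc1`, and compound 2, with structure `CC(C)(C)c1ccc(CN(Cc2cccc(CCC(=O)O)c2)S(C)(=O)=O)cc1`, share a common core and differ only at the group attached to the sulfonyl sulfur. In an assay on HEK293 cells for inhibition of prostaglandin E2 receptor EP4 subtype (Rattus norvegicus) (on this read-out higher numbers stand for weaker inhibition and lower numbers for stronger inhibition), compound 1 gives > 3200 nM, which is a limit of the assay rather than a measured number. In this assay compound 2 likewise gives > 3200 nM, again a limit and not a number. The step that the two limits leave unreadable from compound 1 to compound 2 therefore cannot be read in size, since the limit of > 3200 nM in this assay, at which 2 of the 2 values shown sit, holds both compounds at the same boundary. Compound 2 thus stands at the edge of what the assay can report, with no finer placement available.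

Compound 3, with structure `CCCCc1ccc(CN(Cc2cccc(CCC(=O)O)c2)S(C)(=O)=O)cc1`, keeps the methyl on the sulfonyl sulfur and differs from compound 2 by butyl in place of tert-butyl on an aromatic carbon. Going by the values given here, no measured step bears directly on this change, and the one step that is known is unreadable. With both neighbours at the limit, compound 3 is expected to stay near that boundary, so the estimated step that the limit leaves unreadable from compound 2 to compound 3 is expected to be small or none. The estimate for compound 3 in this assay is 6000 nM, with an expected range from 2000 nM to 20000 nM.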

Compound 3, half-maximal inhibitory concentration: > 3200 nM
Compound 3: only a limit was reported (the forecaster's own chance of this, stated with the estimate: 80%); the middle value does not contradict the limit.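

In this assay compound 3 gives > 3200 nM, again a limit and not a number. Going by these compounds alone, no step from compound 2 to compound 3 can be read, because both stop at the same boundary: the limit of > 3200 nM in this assay, at which 3 of the 3 values shown sit. The compounds shown leave open how strongly compound 1, compound 2 and compound 3 actually inhibit, and whether butyl and tert-butyl differ at all.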